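The source may report more compounds than this note shows. Statements on the series, on what has been measured and on what is new or still open speak of the compounds shown alone.

Of the compounds shown here, three of a shared core have been measured in an assay on SHEP1 cells for displacement of a labelled ligand from Neuronal acetylcholine receptor; alpha4/beta2 (Homo sapiens), read by scintillation counting, with a stated time of 2 h; on this read-out higher numbers stand for weaker inhibition and lower numbers for stronger inhibition. Compound 1 `COC(=O)N1CC2CNCC2C1` gives 23 nM. Compound 2 `O=C(c1ccco1)[C@H]1C[C@@H]2CNC[C@@H](C2)C1` gives 110 nM. Compound 3 `COC(=O)C1CC2CNCC(C2)C1` gives 2400 nM. Among these three numbers compound 2 holds the second highest place: it stands above compound 1 by a gap that lies beyond the scatter of repeated runs, and below compound 3 by a gap that is wider still and also beyond the scatter. Among the compounds with values here, no pair among the three differs in only one place, so no single step between measured compounds can be drawn from them.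

Compound 4 `CCCNC(=O)[C@H]1C[C@@H]2CNC[C@@H](C2)C1` is the next compound and has not yet been measured in this assay. It differs from compound 2 in one respect: propylamino in place of furan-2-yl on a carbonyl carbon. Within the data shown here, the measured compounds give no direct guide for this kind of change, since a ketone replaced by an amide on this carbonyl carbon has no counterpart among them. Compound 4 is expected to be a somewhat weaker binder than compound 2, with a step of a 3.6-fold higher number from compound 2 to compound 4 (0.56 log units; beyond the scatter) estimated in this assay, though the uncertainty is wide. For compound 4 the estimated inhibition constant is 400 nM, within a range from 100 nM to 2000 nM.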

Compound 4, inhibition constant: 6 nM
Compound 4: middle estimate off by 67-fold (1.82 log units), on the high side; measured number below the stated range.
By their numbers in this assay, from the lowest: compound 4; then compound 1; then compound 2; then compound 3.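

In this assay, propylamino in place of furan-2-yl on a carbonyl carbon gives an 18-fold lower number from compound 2 to compound 4 (1.26 log units; beyond the scatter), a large step that shows this position is highly sensitive to what the carbonyl carbon carries. It also shows that, on this core, a low number does not depend on an aromatic ring at this place: the open chain of compound 4 does far better than the five-membered aromatic ring of compound 2. The change, however, removes the ring, turns a ketone into an amide and brings in a hydrogen-bond donor all in one step, and nothing offered here bears on why the number falls so far.

The compounds shown leave open which of these differences carries the step: a plain propyl group on the same carbonyl carbon would keep the chain without the amide nitrogen, while a dimethylamino group would keep that nitrogen without the amide hydrogen. They also leave open how far the chain itself matters, since neither a shorter ethylamino group, a longer butylamino group nor a cyclic amine such as piperidine appears among them.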